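Moving Away From the Highest Number, Compound 3

This account rests on a few compounds, and the source may have more. Where it says the series, first, only, none or still open, it means among the compounds named here.

In a functional assay on PC-3 cells (Homo sapiens), read by MTT assay, with a stated time of 48 h (on this read-out higher numbers stand for weaker inhibition and lower numbers for stronger inhibition), three compounds sharing a core have been measured. Compound 1 (`CCN(CC)CCCNC(=O)c1ccc(C(CC)(CC)c2ccc(OCC(O)C(C)(C)C)c(C)c2)n1CC`) gives 2500 nM, compound 2 (`CCn1c(C(=O)NCCN)ccc1C(CC)(CC)c1ccc(OCC(O)C(C)(C)C)c(C)c1`) gives 940 nM, and compound 3 (`CCn1c(C(=O)N(C)CC(=O)O)ccc1C(CC)(CC)c1ccc(OCC(O)C(C)(C)C)c(C)c1`) gives 23900 nM, the highest of the three numbers.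

Compound 4 (`CCn1c(C(=O)Oc2ccc(CCO)cc2)ccc1C(CC)(CC)c1ccc(OCC(O)C(C)(C)C)c(C)c1`) keeps the core of compound 3 and differs on a carbonyl carbon: a group of 10 heavy atoms (8 carbon, 2 oxygen; one six-membered aromatic ring of carbon only) in place of a group of 6 heavy atoms (3 carbon, 1 nitrogen, 2 oxygen; no ring), on a carbonyl carbon. The group that leaves is (carboxymethyl)(methyl)amino.

Within the data shown here, two measured steps concern this same carbonyl carbon. One is the modest 9.6-fold higher number from compound 1 to compound 3 (0.98 log units; beyond the scatter), and the other is the large 25-fold higher number from compound 2 to compound 3 (1.41 log units; beyond the scatter). Both of the other groups tested there therefore give lower numbers than the group of compound 3. A third step, the modest 2.7-fold lower number from compound 1 to compound 2 (0.42 log units; beyond the scatter), shows that the number also moves with changes within the chain. Neither compound 1 nor compound 2 carries the group that enters in compound 4, and neither has its aromatic ring, so the data give no direct measure of this change.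

A modest step towards a lower number is therefore expected in this assay, smaller than the large step to compound 2. The estimate corresponds to an expected 5.3-fold lower number from compound 3 to compound 4 (0.73 log units; beyond the scatter). For compound 4, the estimated value is 4500 nM, with an expected range from 900 nM to 22000 nM.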

Compound 4, half-maximal inhibitory concentration: 6300 nM
Compound 4: middle estimate off by 1.4-fold (0.15 log units), on the low side; the range from low to high includes it.
By their numbers in this assay, from the lowest: compound 2; then compound 1; then compound 4; then compound 3.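

In this assay, a group on this carbonyl carbon that holds no nitrogen and brings a six-membered aromatic ring of carbon only still moves the number down, with a 3.8-fold lower number from compound 3 to compound 4 (0.58 log units; beyond the scatter). That gain stops short of the two groups that carry an amine, with a 2.5-fold higher number from compound 1 to compound 4 (0.40 log units; beyond the scatter) and a 6.7-fold higher number from compound 2 to compound 4 (0.83 log units; beyond the scatter). Among the four groups now seen on this carbonyl carbon, an amine is therefore not required for a number lower than that of (carboxymethyl)(methyl)amino, although both groups that carry one give lower numbers than the group of compound 4.

The compounds shown do not separate the contribution of the aromatic ring from that of the oxygen on the carbonyl carbon, and they leave open what a group pairing the same aromatic ring with an amine, or with a carboxylic acid, would give. No available evidence bears on what lies behind these differences.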